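Cyclopentyl for sec-butyl on a sulfur: an expected toxicity reading

This account rests on a few compounds, and the source may have more. Where it says the series, first, only, none or still open, it means among the compounds named here.

Values in an ADME assay on MT4 cells (Homo sapiens) for activation, read by MTT assay (on this read-out higher numbers stand for lower toxicity in this test and lower numbers for higher toxicity in this test), all of them limits:
- compound 1 `Cc1c(Cc2c(F)cccc2Cl)nc(SC2CCCC2)[nH]c1=O`: > 71000 nM
- compound 2 `CCCSc1nc(C(C)c2c(F)cccc2Cl)c(C)c(=O)[nH]1`: > 1500 nM
- compound 3 `CCC(C)Sc1nc(C(C)c2c(F)cccc2Cl)c(C)c(=O)[nH]1`: > 1500 nM
- compound 4 `Cc1c(C(C)c2c(F)cccc2Cl)nc(SC2CCCC2)[nH]c1=O`: not yet measured

Compound 3 gives > 1500 nM, which is a limit and not a number. That places compound 3 at the limit of > 1500 nM in this assay, at which 2 of the 3 values shown sit. Compound 4 cyclopentyl in place of sec-butyl on a sulfur carries cyclopentyl in place of sec-butyl on a sulfur.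

Among the measured compounds shown here, only one measured step bears on this part of the structure, a step that the two limits leave unreadable from compound 2 to compound 3. It therefore offers no size and no direction to carry over to this assay.

Compound 1 also has cyclopentyl on a sulfur, and its > 71000 nM is likewise a limit. For the measured compounds named here, that is the sole guide, and it points to low toxicity in this test, with a limit the likely report for compound 4.

The estimated step is a step that the limit leaves unreadable from compound 3 to compound 4, and it remains uncertain in size. For compound 4 the expected value is 30000 nM, with an estimated range from 4000 nM to 150000 nM.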

Compound 4, half-maximal cytotoxic concentration: > 15000 nM
Compound 4: only a limit was reported; the forecaster's own chance of this, stated with the estimate: 70%; the middle value is on the limit's open side.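

In this assay compound 4 gives > 15000 nM, which is a limit and not a number. Among the compounds shown here, the values of compound 1, compound 2 and compound 3 are also limits, so no step to compound 4 can be read. The compounds shown leave open whether cyclopentyl in place of sec-butyl on a sulfur changes this reading at all.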